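Losing the ethoxycarbonyl group from compound 3 to compound 4

The source may hold more compounds than are shown below. What is called first, only, known or untested is meant among the compounds shown, and "the series" means these compounds.

For the measured compounds named here, in an ADME assay on FM3A cells (Mus musculus) (a lower number here means that less compound is needed, a higher number that more compound is needed for the effect), compound 3 `CCOC(=O)C(I)C12CCCC(C1)C(C)(C)OO2` gives 3100 nM, the only true number among the three compounds measured so far. Compound 1 `COC12CCC[C@@H](C1)C(C)(CI)OO2`, which carries no ethoxycarbonyl, is reported only as a limit, > 70000 nM. Compound 2 `CC12CCC[C@@H](C1)C(C)(CI)OO2`, also without ethoxycarbonyl, is likewise reported only as a limit, > 84000 nM.

Compound 4 `CC1(C)OOC2(CI)CCCC1C2` follows from compound 3 by one change: hydrogen in place of ethoxycarbonyl on a saturated chain carbon bound to an iodine atom and a saturated ring carbon. Going by the values given here, the one measured step, a step that the two limits leave unreadable from compound 1 to compound 2, has no readable size and does not involve this group, so no measured step sizes the change directly.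

Compound 2 stays a limit at > 84000 nM, and on that ground compound 4 is expected to need more compound than compound 3 in this assay. The expected change is a 9.7-fold higher number from compound 3 to compound 4 (0.99 log units; beyond the scatter), a large but uncertain estimate. Compound 4 is estimated at 30000 nM, with an expected range of 8000 nM to 90000 nM.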

Compound 4, half-maximal effective concentration: 68000 nM
Estimate against measurement, compound 4: 2.3-fold (0.36 log units) below, within the range that was stated.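

In this assay, putting hydrogen in place of ethoxycarbonyl gives a 22-fold higher number from compound 3 to compound 4 (1.34 log units; beyond the scatter). For the compounds shown here, this is the first step with a readable size; the only earlier step cannot be read. On this saturated chain carbon bound to an iodine atom and a saturated ring carbon, the presence of ethoxycarbonyl therefore goes with much less compound being needed, while compound 4 still gives a true number, 68000 nM. Nothing measured here gives a reason for the size of this step.

From the compounds shown here alone, what stays open is which part of the ethoxycarbonyl group matters, and a carboxylic acid or an amide on the same carbon would help to separate these parts. Going by these compounds, the step also rests on a single pair of compounds, so whether it holds on another core is unknown.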